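From compound 2 to compound 3: an isomer awaits measurement

This account rests on a few compounds, and the source may have more. Where it says the series, first, only, none or still open, it means among the compounds named here.

Compound 1 `Cc1[nH]ncc1-c1cncc(-c2ccc(C(N)=O)c(OC(C)C)c2)c1` gives 8.3 10^-6 cm/s in an ADME assay on Caco-2 cells (Homo sapiens) for permeability; on this read-out higher numbers stand for higher permeability and lower numbers for lower permeability
Compound 2 `Cc1n[nH]c(C)c1-c1cncc(-c2ccc(C(N)=O)c(OC(C)C)c2)c1` gives 6.2 10^-6 cm/s in this assay

Going by the values given here, on the numbers so far, compound 2 has a single measured neighbour and cannot be told apart from it, as the one measured step is a 1.3-fold lower number from compound 1 to compound 2 (0.13 log units; within the scatter) and stays within the scatter. Compound 3 `Cc1c(-c2cncc(-c3ccc(C(N)=O)c(OC(C)C)c3)c2)cnn1C` has the same atoms as compound 2, joined differently, and the change is 1,5-dimethyl-1H-pyrazol-4-yl in place of 3,5-dimethyl-1H-pyrazol-4-yl on an aromatic carbon on the shared core. Among the compounds with values here, no measured pair shows this swap. The nearest evidence is the methyl in place of hydrogen on an aromatic carbon, which is a different kind of change and gave a 1.3-fold lower number from compound 1 to compound 2 (0.13 log units; within the scatter) in this assay without moving beyond the scatter. With so little to go on, no step beyond the scatter is expected, and any lean towards a higher number is tentative. The expected step is a 1.6-fold higher number from compound 2 to compound 3 (0.21 log units; within the scatter) and it remains an estimate. Compound 3 is expected at 10 10^-6 cm/s with an estimated range from 5 10^-6 cm/s to 22 10^-6 cm/s in this assay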

Compound 3, apparent permeability: 27 10^-6 cm/s
For compound 3 the middle estimate is 2.7-fold (0.43 log units) below the measured one; the measured number lies above the stated range.
By their numbers in this assay, from the lowest: compounds 2 and 1 (each within the scatter of the next); then compound 3.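

Placing 1,5-dimethyl-1H-pyrazol-4-yl in place of 3,5-dimethyl-1H-pyrazol-4-yl on the aromatic carbon of the shared core gives a 4.4-fold higher number from compound 2 to compound 3 (0.64 log units; beyond the scatter) in this assay and shows that this position can respond to how the same atoms are joined, which the earlier methyl change on an aromatic carbon did not show. Methyl in place of hydrogen on an aromatic nitrogen gives a 3.3-fold higher number from compound 1 to compound 3 (0.51 log units; beyond the scatter) in the same read-out, so compound 3, whose entering group has 0 hydrogen-bond donors, stands apart from compound 1 and compound 2, and no compound shown goes against this, although this single compound carries the whole contrast. Nothing among the data shown offers an explanation for the size of either step.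

The compounds shown leave open whether an ethyl group or a 2-methoxyethyl chain on that aromatic nitrogen would give a similar number to the methyl group. They also leave open whether the step survives with hydrogen in place of the methyl on the aromatic carbon of the ring, or with an amine on the ring instead.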